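A few compounds are considered here, and "the series" means these few. Any claim that something is new, unique, unknown or untested is made for them only; others in the source may bear on it.

In a functional assay on PC-3 cells (Homo sapiens) for cytotoxicity (on this read-out higher numbers stand for weaker inhibition and lower numbers for stronger inhibition), compound 1 `Nc1[nH]nc2nncc(-c3ccccc3)c12` has the entry "not determined" (no result reported), so it offers no number for comparison. Compound 2 `Nc1nn(Cc2ccccc2)c2nnc(-c3ccccc3)c(-c3ccccc3)c12` gives > 100000 nM, which is a limit of the assay and not a number. Among the compounds with values here, compound 2 therefore has no exact position on this read-out, and the only firm evidence for it is the limit of > 100000 nM in this assay, at which 1 of the 2 values shown sits. Compound 3 `CC(=O)n1nc(N)c2c(-c3ccccc3)c(-c3ccccc3)nnc21` has acetyl in place of benzyl on an aromatic nitrogen. Within the data shown here, no measured step between compounds shows what such a change does in this assay, so the expectation remains loose. The expected step, an at least 2.0-fold lower number from compound 2 to compound 3 (0.30 log units; that floor lies within the scatter), is modest and runs toward stronger inhibition, though compound 3 may well return only a limit too. For compound 3 the estimated half-maximal inhibitory concentration is 50000 nM, with an expected range from 10000 nM to 150000 nM.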

Compound 3, half-maximal inhibitory concentration: > 100000 nM
Compound 3: a limit, no number; the forecaster's own chance of this, stated with the estimate: 50%; middle value at least 2.0-fold (0.30 log units) from the limit.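

In this assay, no step can be read from compound 2 to compound 3, as both entries are limits of the assay and not numbers: the limit of > 100000 nM in this assay, at which 2 of the 3 values shown sit.

The compounds shown leave open whether acetyl in place of benzyl on an aromatic nitrogen changes inhibition at all.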